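The source may report more compounds than this note shows. Statements on the series, on what has been measured and on what is new or still open speak of the compounds shown alone.

Measured so far in an assay for inhibition of Dihydrofolate reductase (Gallus gallus); on this read-out lower numbers stand for stronger inhibition and higher numbers for weaker inhibition:
Compound 1, `CCCCOc1ccccc1Cc1cnc(N)nc1N`: compound 1 gives 8710 nM
Compound 2, `COc1ccccc1Cc1cnc(N)nc1N`: compound 2 gives 28800 nM

Compound 2 stands at the higher of the two numbers in this assay, its nearest neighbour being compound 1, which gives a lower number. Going by the values given here, the only measured step, a 3.3-fold higher number from compound 1 to compound 2 (0.52 log units; beyond the scatter), shows that shortening the chain on the oxygen on the aromatic ring costs potency. The step to compound 3, `CS(=O)(=O)Oc1ccccc1Cc1cnc(N)nc1N`, is a different kind of change: methylsulfonyl in place of methyl on an oxygen on an aromatic ring. Among the compounds with values here, no measured pair covers a sulfonyl group on that oxygen, so the step from compound 1 to compound 2 bears on it only loosely, through the rule that more atoms on this oxygen went with a lower number. On that weak footing a small gain or no change beyond the scatter is expected, with a 1.4-fold lower number from compound 2 to compound 3 (0.16 log units; within the scatter). Compound 3 is therefore estimated at 20000 nM, within a range of 6000 nM to 60000 nM.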

Compound 3, inhibition constant: 22900 nM
For compound 3 the middle estimate is 1.1-fold (0.06 log units) below the measured one; the measured number falls inside the stated range.
By their numbers in this assay, from the lowest: compound 1; then compounds 3 and 2 (each within the scatter of the next).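

In this assay, the change on the oxygen on the aromatic ring from methyl to methylsulfonyl gives a 1.3-fold lower number from compound 2 to compound 3 (0.10 log units; within the scatter), so this swap brings two hydrogen-bond acceptors with no change that can be told from the scatter. Butyl on the same oxygen still holds its place, with a 2.6-fold higher number from compound 1 to compound 3 (0.42 log units; beyond the scatter), so adding atoms here does not by itself lower the number, and compound 3 goes against that simple pattern. Nothing available explains why butyl and methylsulfonyl differ in this way.

The compounds shown leave open whether a chain longer than butyl would lower the number further, or whether ethyl or propyl would already do so. They also leave open how an amine or a carboxylic acid at the end of such a chain would read.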